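This account rests on a few compounds, and the source may have more. Where it says the series, first, only, none or still open, it means among the compounds named here.

Measured compounds:
compound 1 `OCCCCc1cn(CCNc2nonc2/C(=N/O)Nc2ccc(F)c(Br)c2)nn1`, 1080 nM
compound 2 `CCC(C)(O)c1cn(CCNc2nonc2/C(=N/O)Nc2ccc(F)c(Br)c2)nn1`, 958 nM
compound 3 `O/N=C(\Nc1ccc(F)c(Br)c1)c1nonc1NCCn1cc(C2(O)CCCCC2)nn1`, 865 nM

In an assay on isolated protein for inhibition of Indoleamine 2,3-dioxygenase 2 (Homo sapiens) (a higher number here means a weaker inhibitor, a lower number a stronger inhibitor), the three numbers lie close together. Compound 3 gives the lower end of the range, yet the steps of a 1.1-fold lower number from compound 2 to compound 3 (0.04 log units; within the scatter) and a 1.2-fold lower number from compound 1 to compound 3 (0.10 log units; within the scatter) both fall within the scatter, as does a 1.1-fold lower number from compound 1 to compound 2 (0.05 log units; within the scatter). Compound 4 `CC(C)(OCCO)c1cn(CCNc2nonc2/C(=N/O)Nc2ccc(F)c(Br)c2)nn1` differs from compound 3 in one place: 1-(2-hydroxyethoxy)-1-methylethyl in place of 1-hydroxycyclohexyl on an aromatic carbon. All three measured steps exchange one hydroxyl-bearing group for another at this same aromatic carbon, and none moved the number beyond the scatter. The change to compound 4 is of the same kind, so no step beyond the scatter is expected in this assay. Compound 4 is therefore estimated at 900 nM, within 450 nM to 1800 nM, an expected step of a 1.0-fold higher number from compound 3 to compound 4 (0.02 log units; within the scatter).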

Compound 4, half-maximal inhibitory concentration: 1170 nM
Compound 4: the middle estimate sits 1.3-fold (0.11 log units) below what was measured, and the stated range covers the measured number.
By their numbers in this assay, from the lowest: compounds 3, 2, 1 and 4 (each within the scatter of the next).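

In this assay the open chain 1-(2-hydroxyethoxy)-1-methylethyl, which has no ring and carries an ether oxygen, behaves at this aromatic carbon like the earlier hydroxyl-bearing groups, with a 1.4-fold higher number from compound 3 to compound 4 (0.13 log units; within the scatter) and a 1.2-fold higher number from compound 2 to compound 4 (0.09 log units; within the scatter) and also a 1.1-fold higher number from compound 1 to compound 4 (0.03 log units; within the scatter) as the steps. Exchanging the ring of 1-hydroxycyclohexyl for this chain with one more hydrogen-bond acceptor therefore leaves the number within the scatter. Nothing available explains this result. Open, going by these compounds, is whether an amine or a carboxylic acid at this carbon would move the number beyond the scatter.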